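The source may report more compounds than this note shows. Statements on the series, on what has been measured and on what is new or still open speak of the compounds shown alone.

Working notes on the series. In a functional assay on MDA-MB-468 cells (Homo sapiens) for inhibition, read by sulforhodamine B assay, with a stated time of 48 h, tested at 100 uM (a higher number here means a weaker effect of the compound at the concentration tested, a lower number a stronger effect), compound 1 `COc1cc(Cl)cc(-c2nn(-c3cccc(NC(=O)Nc4ccc(Cl)c(C(F)(F)F)c4)c3)cc2-c2ccncc2)c1` gives -27%. Among the measured compounds shown here, compound 2 `COc1cc(Cl)cc(-c2nn(-c3cccc(NC(=O)Nc4cccc(C(F)(F)F)c4)c3)cc2-c2ccncc2)c1` gives -34% in this assay; the only measured step, a number 7 percentage points lower from compound 1 to compound 2 (within the scatter), is hydrogen in place of chloro on an aromatic carbon. Compound 2 thus holds the lower of the two numbers, with compound 1 within the scatter of it, so no order between the two can be read.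

Compound 3 `COc1cc(Cl)cc(-c2nn(-c3cccc(NC(=O)c4cccc(C(F)(F)F)c4)c3)cc2-c2ccncc2)c1` is the next step from compound 2: 3-(trifluoromethyl)phenyl in place of (3-(trifluoromethyl)phenyl)amino on a carbonyl carbon. For the measured compounds named here, the one measured step concerns a chloro on an aromatic ring and does not touch the carbonyl carbon or its amide-type nitrogen neighbour, so nothing measured bears on this change. No step beyond the scatter is therefore expected in this assay; the expected step of a number 4 percentage points higher from compound 2 to compound 3 (within the scatter) is set near zero. For compound 3 the estimate in this assay is -30%, ranging from -65% to 10%.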

Compound 3, a percentage reported as activity, at one concentration (the size of the read-out at that concentration, not a potency): 28%
Beside the measured number, compound 3's estimate is 58 percentage points below it; the whole stated range lies below it.
By their numbers in this assay, from the lowest: compounds 2 and 1 (each within the scatter of the next); then compound 3.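

In this assay, the step at the carbonyl carbon, 3-(trifluoromethyl)phenyl in place of (3-(trifluoromethyl)phenyl)amino, is a number 62 percentage points higher from compound 2 to compound 3 (beyond the scatter), so this position, unlike the chloro site, carries a change beyond the scatter, and the effect at the concentration tested weakens as the amino nitrogen leaves. The step with the chloro-bearing group leaving, (4-chloro-3-(trifluoromethyl)phenyl)amino, is a number 55 percentage points higher from compound 1 to compound 3 (beyond the scatter), which shows the same direction from both amino compounds. Nothing measured on these compounds accounts for the size of this step.

The compounds shown leave open whether the step follows the amino nitrogen itself or its hydrogen. A methylamino or a methylene link to the same aryl group on the carbonyl carbon would separate these two readings.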